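A few compounds are considered here, and "the series" means these few. Any claim that something is new, unique, unknown or untested is made for them only; others in the source may bear on it.

Among the compounds with values here, compound 2 `O=C1NC2(CC2c2ccc3cccc(OCc4ccccc4)c3n2)C(=O)N1C1CCCCC1` gives 300 mg/kg in a functional assay on the whole organism (strain Kunming) with Mus musculus as the target, in the maximal electroshock model, with a stated time of 0.5 h (on this read-out higher numbers stand for an effect only at larger amounts of compound and lower numbers for an effect already at smaller amounts), and stands highest of the two numbers so far; compound 1 `Cc1ccc(N2C(=O)NC3(CC3c3ccc4cccc(OCc5ccccc5)c4n3)C2=O)cc1` gives 100 mg/kg in this assay. Within the data shown here, the only step measured is a 3.0-fold higher number from compound 1 to compound 2 (0.48 log units; beyond the scatter), an exchange on the same ring nitrogen. Compound 3 `CCC(CO)N1C(=O)NC2(CC2c2ccc3cccc(OCc4ccccc4)c3n2)C1=O` differs from compound 2 by 1-(hydroxymethyl)propyl in place of cyclohexyl on an amide-type nitrogen in a ring. Among the measured compounds shown here, no step with a group of this kind is known, so the direction is open; a change in this assay of about the size seen for the one measured step, either way, is expected. For compound 3 the expected value is 200 mg/kg, range 100 mg/kg to 600 mg/kg, meaning an expected step of a 1.5-fold lower number from compound 2 to compound 3 (0.18 log units; within the scatter).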

Compound 3, minimum effective dose: 30 mg/kg
Compound 3: middle estimate off by 6.7-fold (0.82 log units), on the high side; the whole stated range lies above it.
By their numbers in this assay, from the lowest: compound 3; then compound 1; then compound 2.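

On this amide-type ring nitrogen, 1-(hydroxymethyl)propyl gives a 10-fold lower number from compound 2 to compound 3 (1.00 log units; beyond the scatter) and a 3.3-fold lower number from compound 1 to compound 3 (0.52 log units; beyond the scatter) in this assay, so compound 3 holds the lowest of the three numbers and the position is not limited to the upward step seen earlier. This single change removes the carbon ring and brings in the hydroxymethyl group together, so the step cannot be assigned to either. No measured evidence bears on the origin of this step.

Open, from the compounds shown here alone, is whether the hydroxyl or the open chain matters here. A plain sec-butyl chain, or an amine in place of the hydroxyl, on the same nitrogen would separate these.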